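Swapping Dichlorophenyl for Dimethoxyphenyl on a Shared Core

This account rests on a few compounds, and the source may have more. Where it says the series, first, only, none or still open, it means among the compounds named here.

Compound 1 `CCOC(=O)[C@H](CCC(=O)O)NC(=O)c1ccc(CNc2nc3cc(N)cc(N)c3nc2-c2ccccc2)cc1`: < 100000 nM
Compound 2 `Nc1cc(N)c2nc(-c3ccccc3)c(NCc3ccc(Cl)c(Cl)c3)nc2c1`: < 100000 nM

In a functional assay on HCT-15 cells (Homo sapiens) for inhibition, read by sulforhodamine B assay, with a stated time of 48 h (on this read-out lower numbers stand for higher toxicity in this test and higher numbers for lower toxicity in this test), compound 1 gives < 100000 nM, which is a limit of the test rather than a number. Compound 2 likewise gives < 100000 nM, again a limit. Within the data shown here, both values sit at the limit of < 100000 nM in this assay, at which 2 of the 2 values shown sit, so no step between measured compounds can be sized, and compound 2 stands at that limit with nothing to rank it against. Compound 3 `COc1ccc(CNc2nc3cc(N)cc(N)c3nc2-c2ccccc2)cc1OC` differs from compound 2 by 3,4-dimethoxyphenyl in place of 3,4-dichlorophenyl on a saturated chain carbon bound to a nitrogen on an aromatic ring. Among the measured compounds shown here, with no measured step as a guide, no change beyond the usual scatter is expected. Compound 3 is therefore estimated at 30000 nM, with a range from 5000 nM to 100000 nM. The expected step is a step that the limit leaves unreadable from compound 2 to compound 3.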

Compound 3, concentration lethal to 50% of the cells: < 100000 nM
Compound 3: only a limit was reported; the forecaster's own chance of this, stated with the estimate: 65%; the middle value is on the limit's open side.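

Compound 2 and compound 3 each give only a limit, so no step between them can be read: the limit of < 100000 nM in this assay, at which 3 of the 3 values shown sit.

From the compounds shown here alone, the true lethal concentrations of all three compounds remain open, and so does whether 3,4-dimethoxyphenyl in place of 3,4-dichlorophenyl changes anything.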